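A few compounds are considered here, and "the series" means these few. Any claim that something is new, unique, unknown or untested is made for them only; others in the source may bear on it.

In an ADME assay on a cell-free system (plasma, Homo sapiens) for protein binding, tested at 1 uM, compound 2 `O=C(Nc1ccc(OC(F)(F)F)c(F)c1)NC1CCN(C(=O)C2CCCOC2)CC1` gives 99.4%, the lowest unbound fraction of the two compounds measured, while compound 1 `O=C(Nc1ccc(OC(F)(F)F)c(F)c1)NC1CCN(C(=O)C2CCOCC2)CC1` gives 98.5%. For the measured compounds named here, the only measured step at this place is a 2.5-fold lower unbound fraction from compound 1 to compound 2 (0.40 log units; beyond the scatter), with oxan-3-yl in place of oxan-4-yl on a carbonyl carbon. Compound 3 `CCC(=O)N1CCC(NC(=O)Nc2ccc(OC(F)(F)F)c(F)c2)CC1` differs from compound 2 more widely: ethyl in place of oxan-3-yl on a carbonyl carbon. The measured step exchanged one ring for another, so it offers only a loose guide to the size of this change. The estimated step, modest and towards more free compound, is a 3.3-fold higher unbound fraction from compound 2 to compound 3 (0.52 log units; beyond the scatter). Compound 3 is expected to give 98%, within an estimated range of 96% to 99.3%.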

Compound 3, plasma protein binding: 99.2%
Estimate against measurement, compound 3: 2.5-fold (0.40 log units) (unbound fraction) above; measured number inside the range.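

In this assay, the oxan ring is not required at this position for binding to stay this high: the change to ethyl gives a 1.3-fold higher unbound fraction from compound 2 to compound 3 (0.12 log units; within the scatter) and a 1.9-fold lower unbound fraction from compound 1 to compound 3 (0.27 log units; within the scatter) and both steps lie within the scatter, even though the two oxan isomers differ beyond it. Nothing available gives a reason for this. On these data alone, it remains open whether an amine, a carboxylic acid or a longer chain on the carbonyl carbon would leave more of the compound free.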